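Replacing 2-ethoxyethyl with benzyl in a cyano-bearing series

The source may hold more compounds than are shown below. What is called first, only, known or untested is meant among the compounds shown, and "the series" means these compounds.

For the measured compounds named here, in a functional assay on a cell-free system (plasma, Oryctolagus cuniculus) for inhibition, with stated times of 5 min, 1 min and 6 min (on this read-out higher numbers stand for weaker inhibition and lower numbers for stronger inhibition), compound 3 (`CCOCCOn1c(-c2cccc(C#N)c2)nc(C)c1C(=O)OCC`) gives 6250 nM, the lowest of the numbers so far. Compound 1 (`CCOC(=O)c1c(C)nc(-c2ccc(C#N)cc2)n1OC`) stands nearest at 13400 nM, a higher number and a gap beyond the scatter. Compound 2 (`CCOC(=O)c1c(C)nc(-c2ccccc2)n1OC`) is reported only as a limit of the assay, > 30000 nM.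

Compound 4 (`CCOC(=O)c1c(C)nc(-c2cccc(C#N)c2)n1OCc1ccccc1`) departs from compound 3 in one place: phenyl in place of ethoxymethyl on a saturated chain carbon bound to an oxygen on an aromatic ring. Put another way, the 2-ethoxyethyl of compound 3 gives way to benzyl.

Going by the values given here, the only measured step is an at least 2.2-fold higher number from compound 1 to compound 2 (0.35 log units; beyond the scatter), with hydrogen in place of cyano. That step concerns a different place, and compound 4 keeps its cyano group, so the loss seen there is not expected to recur. Among the compounds with values here, no measured step changes the 2-ethoxyethyl chain alone, which leaves both the size and the direction of any shift poorly defined. In this assay the expected outcome is a 1.1-fold higher number from compound 3 to compound 4 (0.05 log units; within the scatter), which would be no step beyond the scatter. For compound 4 the estimated value is 7000 nM, with an expected range of 2000 nM to 25000 nM.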

Compound 4, half-maximal inhibitory concentration: 5930 nM
Compound 4: the middle estimate sits 1.2-fold (0.07 log units) above what was measured, within the range that was stated.
By their numbers in this assay, from the lowest: compounds 4 and 3 (each within the scatter of the next); then compound 1. At a limit, above all of these: compound 2.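

For the compounds shown here, replacing the 2-ethoxyethyl with benzyl gives the first measured step at this position on the oxygen: in this assay it amounts to a 1.1-fold lower number from compound 3 to compound 4 (0.02 log units; within the scatter) and leaves the two compounds indistinguishable. The earlier step, with hydrogen in place of cyano, spoke only for the cyano group, whereas this pair speaks for the chain itself and shows that, with the cyano group kept, the ether oxygen of the ethoxymethyl is not required for the number seen and that a phenyl ring can stand in its place without a shift beyond the scatter. Nothing measured among the compounds shown explains why these two groups read alike.

As far as these compounds go, whether this tolerance reaches beyond a single pair remains open, since it rests only on ethoxymethyl and phenyl at this one place on the chain. From the compounds shown here alone, how a terminal amine or a carboxylic acid on that chain would read, or a longer chain ending in phenyl, and whether any group here could move the number beyond the scatter, remains unknown from these compounds.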